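Side-chain swap on a dichlorophenyl series: carboxy for piperidine

The source may hold more compounds than are shown below. What is called first, only, known or untested is meant among the compounds shown, and "the series" means these compounds.

- Compound 1 `CNC(=O)C[C@@H]1C[C@@H](c2ccc(Cl)c(Cl)c2)[C@H](NC(=O)c2cc(-c3c(Cl)cnn3C)c(Cl)o2)CN1`: 1130 nM
- Compound 2 `Cn1ncc(Cl)c1-c1cc(C(=O)N[C@@H]2CN[C@H](CCN3CCCCC3)C[C@H]2c2ccc(Cl)c(Cl)c2)oc1Cl`: 1660 nM

In a functional assay on OVCAR-8 cells (Homo sapiens) for antiproliferative activity (on this read-out higher numbers stand for weaker inhibition and lower numbers for stronger inhibition), compound 2 gives 1660 nM, which is within the scatter of compound 1: a 1.5-fold higher number from compound 1 to compound 2 (0.17 log units; within the scatter). Compound 3 `Cn1ncc(Cl)c1-c1cc(C(=O)N[C@@H]2CN[C@H](CC(=O)O)C[C@H]2c2ccc(Cl)c(Cl)c2)oc1Cl` carries carboxy in place of (piperidin-1-yl)methyl on a saturated chain carbon bound to a saturated ring carbon. Within the data shown here, only that one measured step bears on this change, and no measured compound carries carboxy, so the range stays wide. No shift beyond the scatter is expected in this assay. The expected change is a 1.5-fold higher number from compound 2 to compound 3 (0.18 log units; within the scatter). For compound 3 the estimated value is 2500 nM, with an expected range of 800 nM to 8000 nM.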

Compound 3, half-maximal inhibitory concentration: 5120 nM
Estimate against measurement, compound 3: 2.0-fold (0.31 log units) below; the range from low to high includes it.
By their numbers in this assay, from the lowest: compounds 1 and 2 (each within the scatter of the next); then compound 3.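

In this assay, this position now shows a shift beyond the scatter: carboxy in place of (piperidin-1-yl)methyl gives a 3.1-fold higher number from compound 2 to compound 3 (0.49 log units; beyond the scatter), and hydroxy in place of methylamino on a carbonyl carbon gives a 4.5-fold higher number from compound 1 to compound 3 (0.66 log units; beyond the scatter). Two different side chains thus sit on the same side of the carboxy compound, so the position is not indifferent to what it carries. Nothing available explains this shift. The compounds shown leave open whether a methyl ester or a primary amide at this carbonyl carbon would read like compound 3 or like compound 1.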